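Working notes on compound 4 in the Vero cytotoxicity series

The compounds below may be only part of what the source reports. "The series", "measured", "known", "first", "only" and "open" are said of these compounds alone.

Among the measured compounds shown here, compound 3 `CN1Cc2ccc(OCc3ccc(Oc4ccc(F)cc4)cc3)cc2[C@@H](O)C1` is the only member of the series with a number in an ADME assay on Vero cells (Chlorocebus sabaeus) for cytotoxicity, read by sulforhodamine B assay, with a stated time of 72 h (on this read-out higher numbers stand for weaker inhibition and lower numbers for stronger inhibition), rather than a limit: compound 3 gives 5600 nM. Compound 1 `CN1Cc2ccc(OCc3ccccc3)cc2[C@@H](O)C1` sits at a limit of this assay, > 100000 nM. Compound 2 `CN1Cc2ccc(OCc3ccc([N+](=O)[O-])cc3)cc2[C@@H](O)C1` also sits at a limit, > 50000 nM. The step that the two limits leave unreadable from compound 1 to compound 2 therefore cannot be sized; the steps of an at least 17-fold lower number from compound 1 to compound 3 (1.25 log units; beyond the scatter) and an at least 8.9-fold lower number from compound 2 to compound 3 (0.95 log units; beyond the scatter) are readable only as lower bounds because of the limit of > 100000 nM in this assay, at which 1 of the 3 values shown sits, and (the limit of > 50000 nM in this assay, at which 1 of the 3 values shown sits).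

Compound 4 `COc1cccc(-c2ccc(COc3ccc4c(c3)[C@@H](O)CN(C)C4)cc2)c1` differs from compound 3 by 3-methoxyphenyl in place of 4-fluorophenoxy on an aromatic carbon. The two measured steps that bear on this position both end at compound 3 and show that a large group there gives a markedly lower number than hydrogen or nitro; neither compares two large groups with each other. The exchange here keeps a group of the same heavy-atom count and acceptor count, so no step beyond the scatter is expected, a 1.1-fold lower number from compound 3 to compound 4 (0.05 log units; within the scatter). Compound 4 is estimated at 5000 nM, with a range from 1800 nM to 15000 nM.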

Compound 4, half-maximal inhibitory concentration: 10800 nM
Beside the measured number, compound 4's estimate is 2.2-fold (0.33 log units) below it; measured number inside the range.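

In this assay, two large groups at this position can now be compared directly: the exchange gives a 1.9-fold higher number from compound 3 to compound 4 (0.29 log units; within the scatter) and so does not separate 3-methoxyphenyl from 4-fluorophenoxy. The lower number is also no longer tied to a single large group, since the change from nitro gives an at least 4.6-fold lower number from compound 2 to compound 4 (0.66 log units; beyond the scatter) and the change from hydrogen gives an at least 9.2-fold lower number from compound 1 to compound 4 (0.96 log units; beyond the scatter). Both of these steps are lower bounds only, because compound 1 and compound 2 each sit at a limit: the limit of > 100000 nM in this assay, at which 1 of the 4 values shown sits, and (the limit of > 50000 nM in this assay, at which 1 of the 4 values shown sits).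

Going by these compounds, it remains open whether an amine or a carboxylic acid in place of the 3-methoxyphenyl would keep the number in the same range. Also open, on these data alone, is how a lone methoxy or a 4-methoxyphenyl would read at this position.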